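A few compounds are considered here, and "the series" means these few. Any claim that something is new, unique, unknown or untested is made for them only; others in the source may bear on it.

Working notes on the series. Among the measured compounds shown here, compound 1 `COc1ccc(/C=C\C(=O)O)c(OCc2cn(-c3cccc(C#N)c3)nn2)c1CC=C(C)C` gives 45500 nM in a functional assay on PC-3 cells (Homo sapiens) for cytotoxicity, read by MTT assay, with a stated time of 24 h; a lower number here means a stronger inhibitor, a higher number a weaker inhibitor; compound 2 `COc1ccc(/C=C\C(=O)O)c(OCc2cn(-c3ccccc3)nn2)c1CC=C(C)C` gives 35000 nM in the same assay, and the step of a 1.3-fold lower number from compound 1 to compound 2 (0.11 log units; within the scatter) is the only one-point comparison in hand. Compound 3 `COc1ccc(/C=C\C(=O)O)c(OCc2cn(-c3nc4ccccc4s3)nn2)c1CC=C(C)C` gives "not determined" (no result reported) in this assay: with no result reported, it stands nowhere on the scale and offers no anchor of its own. Compound 4 `COc1ccc(/C=C\C(=O)O)c(OCc2cn(-c3cccc([N+](=O)[O-])c3)nn2)c1CC=C(C)C` is not yet measured. The change from compound 3 to compound 4 is 3-nitrophenyl in place of 1,3-benzothiazol-2-yl on an aromatic nitrogen. For the measured compounds named here, no measured step touches this exchange directly; what bears on it is only that compound 4 carries a 3-nitrophenyl at the same position where compound 1 carries a cyano-substituted phenyl and compound 2 an unsubstituted phenyl, and the step between those two lay within the scatter. On that footing compound 4 is expected to fall near the values of compound 1 and compound 2 in this assay, with no step beyond the scatter foreseen in either direction. The estimate for compound 4 is 40000 nM, in the range 18000 nM to 90000 nM.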

Compound 4, half-maximal inhibitory concentration: 42100 nM
Estimate against measurement, compound 4: 1.1-fold (0.02 log units) below; the measured number falls inside the stated range.
By their numbers in this assay, from the lowest: compounds 2, 4 and 1 (each within the scatter of the next).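

In this assay, nitro in place of hydrogen on the phenyl gives a 1.2-fold higher number from compound 2 to compound 4 (0.08 log units; within the scatter), and nitro in place of cyano gives a 1.1-fold lower number from compound 1 to compound 4 (0.03 log units; within the scatter). The earlier compounds shown here offered a single substituent exchange on this aryl group; there are now two, and both lie within the scatter. Across compounds 1, 2 and 4, hydrogen, cyano and nitro on the phenyl attached to the triazole nitrogen are not told apart, a reading that holds for these three compounds only.

The exchange of 1,3-benzothiazol-2-yl for 3-nitrophenyl cannot be read, as compound 3 has no reported result, and no evidence in hand bears on the result. Open, as far as these compounds go, is whether an amine or a longer alkyl chain on that phenyl would stay within the scatter of these values.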